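Swapping nitro for methoxy in a small series

The compounds below may be only part of what the source reports. "The series", "measured", "known", "first", "only" and "open" are said of these compounds alone.

compound 1 (`Cc1cc(Nc2cc(N3CCN(C)CC3)nc(Nc3ccc([N+](=O)[O-])cc3)n2)n[nH]1`) gives 1200 nM
compound 2 (`Cc1cc(Nc2cc(N3CCN(C)CC3)nc(Nc3cccc(Cl)c3)n2)n[nH]1`) gives 3090 nM
compound 3 (`Cc1cc(Nc2cc(N3CCN(C)CC3)nc(Nc3ccc(C#N)cc3)n2)n[nH]1`) gives 1270 nM

All three numbers come from a functional assay on DU-145 cells (Homo sapiens) for antiproliferative activity, read by CCK-8 assay, with a stated time of 72 h (a higher number here means a weaker inhibitor, a lower number a stronger inhibitor), and the three compounds share one core. Compound 1 and compound 3 sit level, as a 1.1-fold higher number from compound 1 to compound 3 (0.02 log units; within the scatter) shows. Compound 2 stands apart from that pair by a modest gap, as a 2.6-fold higher number from compound 1 to compound 2 (0.41 log units; beyond the scatter) and a 2.4-fold lower number from compound 2 to compound 3 (0.39 log units; beyond the scatter) show.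

The next compound to be measured is compound 4 (`COc1ccc(Nc2nc(Nc3cc(C)[nH]n3)cc(N3CCN(C)CC3)n2)cc1`). Its difference from compound 1 is methoxy in place of nitro on an aromatic carbon and, in short, it is methoxy in place of nitro on an aromatic carbon, para to a large group.

Among the compounds with values here, two steps bear on this change. Swapping nitro for cyano on an aromatic carbon gave a 1.1-fold higher number from compound 1 to compound 3 (0.02 log units; within the scatter) and so made no real difference. Replacing the whole 4-nitrophenyl with 3-chlorophenyl gave a 2.6-fold higher number from compound 1 to compound 2 (0.41 log units; beyond the scatter) and so shows that this part of the molecule can shift the number modestly. Neither step tests methoxy, so the direction is uncertain, but a modest rise is expected rather than a fall. The expected size is a 1.8-fold higher number from compound 1 to compound 4 (0.26 log units; within the scatter) and this remains an estimate. The estimated value for compound 4 is 2200 nM with an expected range from 1000 nM to 5000 nM in this assay once it is measured.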

Compound 4, half-maximal inhibitory concentration: 5050 nM
Estimate against measurement, compound 4: 2.3-fold (0.36 log units) below; measured number outside the range, above it.
By their numbers in this assay, from the lowest: compounds 1 and 3 (each within the scatter of the next); then compounds 2 and 4 (each within the scatter of the next).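

Swapping nitro for methoxy shows that the group on this aromatic carbon can change the number in this assay (a 4.2-fold higher number from compound 1 to compound 4 (0.62 log units; beyond the scatter)), even though the earlier swap from nitro to cyano did not (a 1.1-fold higher number from compound 1 to compound 3 (0.02 log units; within the scatter)). Methoxy also separates from cyano by a similar amount (a 4.0-fold higher number from compound 3 to compound 4 (0.60 log units; beyond the scatter)), so among these three groups at this place, methoxy is the one that stands apart, while nitro and cyano remain level. The whole 4-methoxyphenyl group cannot be told apart from 3-chlorophenyl (a 1.6-fold higher number from compound 2 to compound 4 (0.21 log units; within the scatter)), so the four compounds now fall into two pairs, and nothing measured here explains why methoxy falls with the 3-chlorophenyl compound rather than with nitro and cyano.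

Going by these compounds, it remains open whether an amine, a carboxylic acid or a longer chain such as ethoxy on this same aromatic carbon would join the pair of compound 1 and compound 3 or the pair of compound 2 and compound 4. With only one substituent at a time and one cell line shown, these two pairs describe four compounds and cannot yet be read as a general rule for this position.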